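One Oxygen Added at the Far End of the Chain

This account rests on a few compounds, and the source may have more. Where it says the series, first, only, none or still open, it means among the compounds named here.

Four compounds share a long, rod-like core in which a chain of three benzene rings links a benzimidazole to a fluorinated end group. Compound 1 `FC(F)(F)c1ccc(-c2ccc(-c3ccc(-c4nc5ccccc5[nH]4)cc3)cc2)cc1` carries a trifluoromethyl group at that end and, in a functional assay on HOP-62 cells (Homo sapiens) for inhibition, read by sulforhodamine B assay (on this read-out lower numbers stand for stronger inhibition of growth and higher numbers for weaker inhibition of growth), compound 1 gives 100000 nM. Compound 2 `FC(F)(F)Oc1ccc(-c2ccc(-c3ccc(-c4nc5ccccc5[nH]4)cc3)cc2)cc1` differs from it only by trifluoromethoxy in place of trifluoromethyl on an aromatic carbon, and in this assay compound 2 gives 100000 nM, so that no change at the digits printed from compound 1 to compound 2 (within the scatter).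

Compound 3 `Oc1cccc2[nH]c(-c3ccc(-c4ccc(-c5ccc(C(F)(F)F)cc5)cc4)cc3)nc12` differs from compound 1 by hydroxy in place of hydrogen on an aromatic carbon. In this assay compound 3 gives 3200 nM, and a 31-fold lower number from compound 1 to compound 3 (1.49 log units; beyond the scatter). Among the three measured compounds, compound 3 therefore stands at the lowest number.

Compound 4 `Oc1cccc2[nH]c(-c3ccc(-c4ccc(-c5ccc(OC(F)(F)F)cc5)cc4)cc3)nc12` has not yet been measured. Going by the values given here, it differs from compound 3 by trifluoromethoxy in place of trifluoromethyl on an aromatic carbon, which is the same change as the one between compound 1 and compound 2, at the same place and with the same groups leaving and entering. Among the compounds with values here, the only guide to this change is the step from compound 1 to compound 2, where it made no difference within the scatter, although both of those numbers are very high and that pair may not reveal much about a far lower starting point. The step from compound 3 to compound 4 in this assay is expected to be small, no change at the digits printed from compound 3 to compound 4 (within the scatter), resting on compound 1 and compound 2 and the step of no change at the digits printed from compound 1 to compound 2 (within the scatter). Compound 4 is thus estimated to give 3200 nM in this assay, with a plausible range from 1200 nM to 9000 nM.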

Compound 4, concentration for 50% growth inhibition: 2270 nM
Beside the measured number, compound 4's estimate is 1.4-fold (0.15 log units) above it, and the stated range covers the measured number.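

In this assay, putting trifluoromethoxy in place of trifluoromethyl on the core that carries the hydroxy gives a 1.4-fold lower number from compound 3 to compound 4 (0.15 log units; within the scatter), so this swap leaves the growth-inhibition number about where it was, and it behaves alike on both cores: the same change on two cores in this assay, no change at the digits printed (within the scatter) from compound 1 to compound 2 and a 1.4-fold lower number (0.15 log units; within the scatter) from compound 3 to compound 4, 1.4-fold (0.15 log units) apart, within the scatter of two such steps

Seen the other way, adding the hydroxy to the trifluoromethoxy compound gives a 44-fold lower number from compound 2 to compound 4 (1.64 log units; beyond the scatter), a large step that matches the one seen with trifluoromethyl at the end of the chain: the same change on two cores in this assay, a 31-fold lower number (1.49 log units; beyond the scatter) from compound 1 to compound 3 and a 44-fold lower number (1.64 log units; beyond the scatter) from compound 2 to compound 4, 1.4-fold (0.15 log units) apart, within the scatter of two such steps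

Going by these compounds alone, this agreement rests on only two pairs, so it shows that each change carried over between these cores, not that it would do so on any other core, and it says nothing about why the hydroxy matters so much or why the end-group swap matters so little.

As far as these compounds go, whether a different end group, such as a nitrile or an amine, would fit the same picture remains open, as does whether a methoxy group in place of the hydroxy would keep the lower numbers. Also open, from the compounds shown here alone, is whether the same steps would appear in cells other than those of this assay.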